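The source may report more compounds than this note shows. Statements on the series, on what has been measured and on what is new or still open speak of the compounds shown alone.

Measured so far:
- compound 1 `O=C(NN1CCOCC1)c1c(O)c2cccnc2n(-c2ccccc2)c1=O`: -8.5%
- compound 2 `O=C(Nc1ccc(Cl)cc1)c1c(O)c2cccnc2n(-c2ccccc2)c1=O`: 11.6%

Among the compounds with values here, in a functional assay on the whole organism for inhibition, with Rattus norvegicus as the target, read by paw edema, at a dose of 100 mg/kg by the oral route (a lower number here means less inhibition, a higher number more inhibition at the dose given (going by the name of the read-out)), compound 2 stands highest of the two numbers, and the only recorded step, a number 20.1 percentage points higher from compound 1 to compound 2 (beyond the scatter), lies beyond the scatter. Compound 3 `Cc1cccc(NC(=O)c2c(O)c3cccnc3n(-c3ccccc3)c2=O)c1` has not been measured yet. The change is 3-methylphenyl in place of 4-chlorophenyl on an amide-type nitrogen. The recorded step swaps a non-aromatic group for an aromatic one on that nitrogen, whereas here one aromatic group replaces another, so it bears only loosely on this case. The expected shift is therefore small, a number 2.6 percentage points lower from compound 2 to compound 3 (within the scatter), within the scatter. Compound 3 is estimated at 9%, with a range from -11% to 29%.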

Compound 3, a percentage reported as inhibition, in the whole organism at one dose (the size of the read-out at that dose, not a potency): 14.2%
Beside the measured number, compound 3's estimate is 5.2 percentage points below it; low and high end bracket the measured number.
By their numbers in this assay, from the lowest: compound 1; then compounds 2 and 3 (each within the scatter of the next).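

In this assay, one substituted phenyl group replacing another on the amide-type nitrogen gives a number 2.6 percentage points higher from compound 2 to compound 3 (within the scatter), so 4-chlorophenyl and 3-methylphenyl cannot be told apart here. Replacing morpholin-4-yl with 3-methylphenyl gives a number 22.7 percentage points higher from compound 1 to compound 3 (beyond the scatter), so both aromatic groups now stand apart from morpholin-4-yl. Nothing available explains these numbers.

On these data alone, it remains open whether an aromatic ring on this nitrogen is needed at all, or whether a plain hexyl chain would serve as well. A phenyl group carrying a carboxylic acid or an amine is also untested among the compounds shown.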